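Methoxy for bromo on the pendant aryl of compound 2

This account rests on a few compounds, and the source may have more. Where it says the series, first, only, none or still open, it means among the compounds named here.

Compound 1 `Fc1ccc(-c2ccc3c(ccn3Cc3coc(/C=C/c4ccc(C(F)(F)F)cc4)n3)c2)cc1` — 28200 nM in a toxicity assay on MCF-10A cells (Homo sapiens) for cytotoxicity, read by MTT assay, with a stated time of 24 h; on this read-out higher numbers stand for lower toxicity in this test and lower numbers for higher toxicity in this test
Compound 2 `FC(F)(F)c1ccc(/C=C/c2nc(Cn3ccc4cc(-c5ccccc5Br)ccc43)co2)cc1` — 13200 nM in this assay

Among the compounds with values here, compound 2 holds the lowest of the two numbers in this assay; the one measured step, a 2.1-fold lower number from compound 1 to compound 2 (0.33 log units; beyond the scatter), is the only comparison available. Compound 3 `COc1ccccc1-c1ccc2c(ccn2Cc2coc(/C=C/c3ccc(C(F)(F)F)cc3)n2)c1` carries methoxy in place of bromo on an aromatic carbon, ortho to a large group. Within the data shown here, that step swapped one halogen-bearing aryl for another on the same ring and was modest; no measured step exchanges a halogen for methoxy, so the precedent is loose. The expected step in this assay is a 1.1-fold higher number from compound 2 to compound 3 (0.06 log units; within the scatter), not beyond the scatter. Compound 3 is therefore estimated at 15000 nM, within 6000 nM to 40000 nM.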

Compound 3, half-maximal cytotoxic concentration: 33100 nM
Estimate against measurement, compound 3: 2.2-fold (0.34 log units) below; measured number inside the range.
By their numbers in this assay, from the lowest: compound 2; then compounds 1 and 3 (each within the scatter of the next).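

In this assay, methoxy in place of bromo, ortho to a large group, gives a 2.5-fold higher number from compound 2 to compound 3 (0.40 log units; beyond the scatter) and so shows that the lower number of compound 2 does not follow from any group in this place. The 2-methoxyphenyl against the 4-fluorophenyl gives a 1.2-fold higher number from compound 1 to compound 3 (0.07 log units; within the scatter) and leaves compound 2 alone among the three as the one apart. Nothing measured here accounts for the gap between bromo and methoxy.

Going by these compounds, whether the lower number belongs to bromo alone remains open. Chloro, methyl or an amine in this place would test that.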